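This account rests on a few compounds, and the source may have more. Where it says the series, first, only, none or still open, it means among the compounds named here.

Measured compounds and their values:

Compound 1 `Nc1cc(-c2ccc(Br)cc2)nc2cc(-c3ccc(Cl)cc3)nn12`, which in a functional assay on the whole organism (strain Wistar) for inhibition, with Rattus norvegicus as the target, read by paw edema, with stated times of 30 min and 1 h, at a dose of 50 mg/kg by the oral route (a lower number here means less inhibition, a higher number more inhibition at the dose given (going by the name of the read-out)), gives 59.6%.
Compound 2 `Cc1ccc(-c2cc(N)n3nc(-c4ccc(Cl)cc4)cc3n2)cc1`, which in this assay gives 57.7%.
Compound 3 `Cc1ccc(-c2cc3nc(-c4ccc(Cl)cc4)cc(N)n3n2)cc1`, which in this assay gives 59.6%.

Within the data shown here, the three values lie close together, and no compound can be singled out as having the highest number. Compound 1 arises from compound 2 by one change, (bromo in place of methyl on an aromatic carbon), and this step reads a number 1.9 percentage points higher from compound 2 to compound 1 (within the scatter). Compound 3 shares its atoms with compound 2 but joins them differently; the difference between the two cores is not broken down here.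

Compound 4 `Nc1cc(-c2ccc(Cl)cc2)nc2cc(-c3ccc(Br)cc3)nn12` has not yet been measured. It differs from compound 3 by bromo in place of methyl on an aromatic carbon, and the place of this change is described in the same words as for the step from compound 2 to compound 1, so it is the same change made on the core of compound 3. Because the earlier step was a number 1.9 percentage points higher from compound 2 to compound 1 (within the scatter), a step of similar size is expected here: a number 1.4 percentage points higher from compound 3 to compound 4 (within the scatter). For compound 4 the estimate in this assay is 61%, expected to fall between 50% and 72%.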

Compound 4, a percentage reported as inhibition, in the whole organism at one dose (the size of the read-out at that dose, not a potency): 13.5%
The estimate for compound 4 lay 47.5 percentage points above the measured number; the measured number lies below the stated range.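

In this assay, replacing 4-methylphenyl with 4-bromophenyl gives a number 46.1 percentage points lower from compound 3 to compound 4 (beyond the scatter), and the two steps for this change do not agree: the same change on two cores in this assay, a number 1.9 percentage points higher (within the scatter) from compound 2 to compound 1 and a number 46.1 percentage points lower (beyond the scatter) from compound 3 to compound 4, 48 percentage points apart, beyond the scatter of two such steps This shows that, in this series, the result of this change depends on the core that carries it, so a step read on one core is a poor guide to the same step on the other. Among these compounds, it does not show why the two cores part ways, and with only two steps, each from a single read-out in the whole animal at one dose, it gives no general rule for further cores.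

The compounds shown carry only methyl or bromo at this place, so it remains open whether the sharp loss of inhibition on the core of compound 3 is particular to bromo. A methoxy group or a carboxylic acid at the same place could show whether other groups also behave differently on the two cores.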